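The source may report more compounds than this note shows. Statements on the series, on what has been measured and on what is new or still open speak of the compounds shown alone.

Measured so far in a physicochemical assay for solubility, in phosphate buffer, at pH 7.4; a lower number here means a less soluble compound, a higher number a more soluble compound:
- compound 1 `OCC1CCN(c2nccnc2OC2CN(c3cnc4ccccc4n3)C2)CC1` gives 500000 nM
- compound 2 `OCC1CCN(c2nccnc2OC2CN(c3ncc4ccccc4n3)C2)CC1` gives 174000 nM
- compound 3 `OCc1cccc(-c2nccnc2OC2CN(c3ccc4ccccc4n3)C2)c1` gives 29000 nM

Compound 3 has the lowest number of the three, and its gaps to compound 2 and to compound 1 both lie beyond the scatter. Compound 4 `c1ccc2nc(N3CC(Oc4nccnc4-c4cccc5ncccc45)C3)ccc2c1` has not been measured yet. It carries quinolin-5-yl in place of 3-(hydroxymethyl)phenyl on an aromatic carbon of the shared core. For the measured compounds named here, no measured pair shows a single change like this one, so the expectation is only a judgement, anchored on compound 3 at 29000 nM in this assay and pointing to a moderately lower number, beyond the scatter. The expected size is a 3.2-fold lower number from compound 3 to compound 4 (0.51 log units; beyond the scatter) on this estimate. Compound 4 is expected at 9000 nM with an estimated range from 2000 nM to 40000 nM in this measurement.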

Compound 4, solubility: 47000 nM
Beside the measured number, compound 4's estimate is 5.2-fold (0.72 log units) below it; the whole stated range lies below it.
By their numbers in this assay, from the lowest: compounds 3 and 4 (each within the scatter of the next); then compound 2; then compound 1.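

In this assay, for the compounds shown here, putting quinolin-5-yl in place of 3-(hydroxymethyl)phenyl on this aromatic carbon gives a 1.6-fold higher number from compound 3 to compound 4 (0.21 log units; within the scatter), the first comparison here that isolates a single change. The hydroxymethyl group's hydrogen-bond donor leaves and a larger two-ring group enters, yet the two compounds cannot be told apart in this measurement. Nothing measured here offers an explanation for this result. Still open, on these data alone, is how an amine or a carboxylic acid on this carbon would compare with compound 3. Whether the same swap would read alike on the core of compound 1 is also unknown.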